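The source may hold more compounds than are shown below. What is called first, only, known or untested is meant among the compounds shown, and "the series" means these compounds.

Compound 2 `CCCSc1nsnc1[C@H]1CN2CCC[C@H]1C2` is a mirror-image variant of compound 1 `CCCSc1nsnc1[C@@H]1CN2CCC[C@H]1C2` at one ring carbon. In a functional assay on the whole organism with Mus musculus as the target (on this read-out lower numbers stand for an effect already at smaller amounts and higher numbers for an effect only at larger amounts of compound), compound 1 gives 1.3 mg/kg. On these data alone, for compound 2 this assay reports only a limit, > 30 mg/kg, so its exact position is unknown. The step of an at least 23-fold higher number from compound 1 to compound 2 (1.36 log units; beyond the scatter) shows that redrawing that one centre removes the measurable effect, an outcome that rests on the limit of > 30 mg/kg in this assay, at which 1 of the 2 values shown sits, and on (the fact that one of compounds 1 and 2 is drawn with a defined configuration and the other without, at the place where they differ).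

Compound 3 `CCCSc1nsnc1[C@@H]1CN2CCC[C@@H]1C2` differs from compound 2 by the two compounds have the same atoms and bonds; at least one stereo element is drawn with a configuration in one of them and without one in the other: 2 of 3 stereo elements differ; a stereocentre at a saturated ring carbon is drawn R in compound 2 and S in compound 3; a stereocentre at a saturated ring carbon is drawn R in compound 2 and S in compound 3. Within the data shown here, no measured step covers a change at two ring centres at once, and the single-centre step from compound 1 to compound 2 was large, so the configuration at these saturated ring carbons clearly governs the read-out. On that basis compound 3 is expected to regain part of the effect, a step of an at least 7.5-fold lower number from compound 2 to compound 3 (0.87 log units; beyond the scatter). Compound 3 is therefore estimated at 4 mg/kg, with a range from 0.8 mg/kg to 30 mg/kg.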

Compound 3, dose for half-maximal effect: > 30 mg/kg
Compound 3: only a limit was reported; the forecaster's own chance of this, stated with the estimate: 30%; at least 7.5-fold (0.87 log units) between middle value and limit.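

With an at least 23-fold higher number from compound 1 to compound 3 (1.36 log units; beyond the scatter), a second ring carbon of the shared core also proves decisive: redrawing either of the two centres in compound 1 leaves no measurable effect up to the highest reported dose. In this assay, compound 3 gives only a limit, > 30 mg/kg. The step from compound 2 to compound 3 cannot be read, and the size of the step from compound 1 to compound 3 is only a minimum, resting on this: the limit of > 30 mg/kg in this assay, at which 2 of the 3 values shown sit.

On these data alone, how far compound 2 and compound 3 actually lie beyond that limit, and whether they differ from each other at all, stays open. So does whether the configuration of compound 1 would keep its effect with a longer chain or an amine in place of the sulfur-linked propyl chain.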